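Isobutyl to cyclopropyl, carried from compound 1 to compound 3

The source may hold more compounds than are shown below. What is called first, only, known or untested is meant among the compounds shown, and "the series" means these compounds.

Measured so far in a functional assay on CHO cells for positive allosteric modulation of metabotropic glutamate receptor 2 (Homo sapiens), read by scintillation counting and GTPgammaS binding, with a stated time of 30 min; a lower number here means a smaller maximal response, a higher number a larger maximal response:
compound 1 `Cc1cc(Oc2ccc(-c3ccn(CCC(C)C)c(=O)c3C#N)cc2)ccn1` gives 266%
compound 2 `Cc1cc(Oc2ccc(-c3ccn(CC4CC4)c(=O)c3C#N)cc2)ccn1` gives 199%
compound 3 `Cc1ncccc1Oc1ccc(-c2ccn(CCC(C)C)c(=O)c2C#N)cc1` gives 256%

Compound 1 and compound 2 differ in one place: cyclopropyl in place of isobutyl on a saturated chain carbon bound to an aromatic nitrogen. This change made a large step, a number 67 percentage points lower from compound 1 to compound 2 (beyond the scatter).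

Compound 1 and compound 3 share everything except the group on the oxygen: 2-methylpyridin-3-yl in place of 2-methylpyridin-4-yl on an oxygen on an aromatic ring. Here the step was a number 10 percentage points lower from compound 1 to compound 3 (within the scatter), so compound 1 and compound 3 are not told apart by this assay.

Compound 4 `Cc1ncccc1Oc1ccc(-c2ccn(CC3CC3)c(=O)c2C#N)cc1` is not yet measured. It stands to compound 3 as compound 2 stands to compound 1: cyclopropyl in place of isobutyl on a saturated chain carbon bound to an aromatic nitrogen. The place is the same in both pairs, so this is the same change made on the other core. Going by the values given here, only one instance of it has been measured, so there is no check on how far it transfers. Taking the step from compound 1 to compound 2 as the guide, and because compound 3 sits at 256%, compound 4 is expected to move by a number 67 percentage points lower from compound 3 to compound 4 (beyond the scatter) in this assay. The estimate for compound 4 is 189%, with a likely range from 150% to 230%.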

Compound 4, largest response reached (Emax), in percent of the reference or control that the assay uses: 155%
Compound 4: middle estimate off by 34 percentage points, on the high side; the measured number falls inside the stated range.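

Notes on the series: in this assay, cyclopropyl in place of isobutyl lowers the maximal response on both cores, with a step of a number 101 percentage points lower from compound 3 to compound 4 (beyond the scatter), so the direction carries over but the size does not: the same change on two cores in this assay, a number 67 percentage points lower (beyond the scatter) from compound 1 to compound 2 and a number 101 percentage points lower (beyond the scatter) from compound 3 to compound 4, 34 percentage points apart, beyond the scatter of two such steps

The 2-methylpyridin-3-yl for 2-methylpyridin-4-yl change, which could not be told apart from scatter with isobutyl in place, gives a number 44 percentage points lower from compound 2 to compound 4 (beyond the scatter) with cyclopropyl, so the two changes do not add up independently in this set: the same change on two cores in this assay, a number 10 percentage points lower (within the scatter) from compound 1 to compound 3 and a number 44 percentage points lower (beyond the scatter) from compound 2 to compound 4, 34 percentage points apart, beyond the scatter of two such steps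

Both comparisons rest on the same four compounds and describe a single non-additive set, which shows that the step depends on the core here but gives neither a reason for this nor a rule for a further core.

Still open, as far as these compounds go, is whether the dependence on the core persists with other groups on the saturated chain carbon bound to the aromatic nitrogen, such as a longer chain or a cyclobutyl group. From the compounds shown here alone, it is also open whether a chain ending in an amine or a carboxylic acid would follow either step.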